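Swapping 4-methylphenyl for 3-hydroxyphenyl in compound 3

This account rests on a few compounds, and the source may have more. Where it says the series, first, only, none or still open, it means among the compounds named here.

Values measured in an ADME assay on L132 cells (Homo sapiens) for cytotoxicity, read by MTT assay, with a stated time of 48 h; on this read-out higher numbers stand for weaker inhibition and lower numbers for stronger inhibition:
Compound 1 (`C/C(=C\CC/C(C)=C/CC[C@@H]1[C@@]2(C)CCC(=O)C(C)(C)[C@H]2CC[C@@]1(C)O)CC/C=C(\C)C(=O)OCc1cn(-c2ccc(F)cc2)nn1`) gives > 150000 nM as a limit
Compound 2 (`C/C(=C\CC/C(C)=C/CC[C@@H]1[C@@]2(C)CCC(=O)C(C)(C)[C@H]2CC[C@@]1(C)O)CC/C=C(\C)C(=O)OCc1cn(-c2cccc(Cl)c2)nn1`) gives 94200 nM as a number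
Compound 3 (`C/C(=C\CC/C(C)=C/CC[C@@H]1[C@@]2(C)CCC(=O)C(C)(C)[C@H]2CC[C@@]1(C)O)CC/C=C(\C)C(=O)OCc1cn(-c2ccc(C)cc2)nn1`) gives > 150000 nM as a limit

Compound 3 reports only the limit > 150000 nM and no number. This is the limit of > 150000 nM in this assay, at which 2 of the 3 values shown sit, and it leaves the starting point of the next step open.

Compound 4 (`C/C(=C\CC/C(C)=C/CC[C@@H]1[C@@]2(C)CCC(=O)C(C)(C)[C@H]2CC[C@@]1(C)O)CC/C=C(\C)C(=O)OCc1cn(-c2cccc(O)c2)nn1`) carries 3-hydroxyphenyl in place of 4-methylphenyl on an aromatic nitrogen and keeps the shared core of compound 3.

Three measured steps change the group on that same nitrogen. The series shows an at least 1.5-fold higher number from compound 2 to compound 3 (0.20 log units; that floor lies within the scatter) on going to 4-methylphenyl from 3-chlorophenyl. It also shows an at least 1.5-fold lower number from compound 1 to compound 2 (0.20 log units; that floor lies within the scatter) on going to 3-chlorophenyl from 4-fluorophenyl. The third is a step that the two limits leave unreadable from compound 1 to compound 3 and gives no size. No measured step is shown to exceed the scatter, and compound 2 at 94200 nM is the only number available. No clear step is therefore expected for this swap in either direction. The expected step reads an at least 1.2-fold lower number from compound 3 to compound 4 (0.09 log units; that floor lies within the scatter) and nothing beyond the scatter is anticipated. In this assay compound 4 is estimated at 120000 nM with a range from 55000 nM to 220000 nM expected for it.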

Compound 4, half-maximal inhibitory concentration: 146000 nM
For compound 4 the middle estimate is 1.2-fold (0.09 log units) below the measured one; the range from low to high includes it.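

In this assay, putting hydroxy in place of chloro on an aromatic carbon gives a 1.5-fold higher number from compound 2 to compound 4 (0.19 log units; within the scatter), so the two groups on this aromatic nitrogen that yield actual numbers lie within the scatter of each other. Within the data shown here, this is the first group with a hydrogen-bond donor, and the one step between numbers that includes such a group shows no change beyond the scatter. The steps that start from the other two compounds are an at least 1.0-fold lower number from compound 3 to compound 4 (0.01 log units; that floor lies within the scatter) and an at least 1.0-fold lower number from compound 1 to compound 4 (0.01 log units; that floor lies within the scatter), and they give only floors that lie within the scatter, without a readable size, as each starts from a limit: the limit of > 150000 nM in this assay, at which 2 of the 4 values shown sit.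

The series therefore contains no step on this nitrogen that is shown to exceed the scatter, and the true distance of compound 1 and compound 3 from the two numbers stays unknown. As far as these compounds go, what an amine or a carboxylic acid on the phenyl ring, or a longer chain between the phenyl ring and the five-membered aromatic ring, would do on this read-out also stays open.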